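Swapping the aryl on the nitrogen-rich ring

A few compounds are considered here, and "the series" means these few. Any claim that something is new, unique, unknown or untested is made for them only; others in the source may bear on it.

Of the compounds shown here, three sharing one core have been tested in a functional assay on MCF7 cells (Homo sapiens) for antiproliferative activity, read by MTT assay, with a stated time of 48 h; a higher number here means a weaker inhibitor, a lower number a stronger inhibitor. Compound 1 `N#CC1=C(N)Oc2c(c3nc4ccccc4nc3c3ccccc23)C12C(=O)N(Cc1cnnn1-c1ccc(Cl)cc1)c1ccccc12` carries a 4-chlorophenyl on an aromatic nitrogen; in this assay compound 1 reaches only the limit of the assay at > 50000 nM. Compound 2 `N#CC1=C(N)Oc2c(c3nc4ccccc4nc3c3ccccc23)C12C(=O)N(Cc1cnnn1-c1ccccc1Br)c1ccccc12` bears a 2-bromophenyl in the same place, and in this assay compound 2 likewise stops at the limit, > 50000 nM. Going by the values given here, compound 3 `N#CC1=C(N)Oc2c(c3nc4ccccc4nc3c3ccccc23)C12C(=O)N(Cc1cnnn1-c1cccc(S(N)(=O)=O)c1)c1ccccc12`, with a 3-sulfamoylphenyl, is the only member that returns a number: in this assay compound 3 gives 42500 nM, just inside the reporting window. The steps of an at least 1.1-fold lower number from compound 1 to compound 3 (0.07 log units; that floor lies within the scatter) and an at least 1.1-fold lower number from compound 2 to compound 3 (0.07 log units; that floor lies within the scatter) are read against that limit, and a step that the two limits leave unreadable from compound 1 to compound 2 cannot be read at all, both partners sitting at the limit of > 50000 nM in this assay, at which 2 of the 3 values shown sit.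

Compound 4 `Cc1ccc(C)c(-n2nncc2CN2C(=O)C3(C(C#N)=C(N)Oc4c3c3nc5ccccc5nc3c3ccccc43)c3ccccc32)c1` has not been measured. It differs from compound 3 in one place: 2,5-dimethylphenyl in place of 3-sulfamoylphenyl on an aromatic nitrogen. Among the compounds with values here, the steps that bear on this swap, an at least 1.1-fold lower number from compound 1 to compound 3 (0.07 log units; that floor lies within the scatter) and an at least 1.1-fold lower number from compound 2 to compound 3 (0.07 log units; that floor lies within the scatter), show only that two other aryl groups left their compounds at the limit. No change beyond the scatter is therefore expected, and the expected step is a 1.4-fold higher number from compound 3 to compound 4 (0.15 log units; within the scatter). For compound 4 the estimate in this assay is 60000 nM, within 25000 nM to 150000 nM, with a fair chance that only a limit is reported.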

Compound 4, half-maximal inhibitory concentration: > 50000 nM
Compound 4: a limit, no number (the forecaster's own chance of this, stated with the estimate: 60%); the middle value lies beyond the limit too.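

In this assay, going by these compounds alone, compound 4 gives only a limit, so a 2,5-dimethylphenyl, an aryl group of carbon alone with no hydrogen-bond donors or acceptors, joins the 4-chlorophenyl of compound 1 and the 2-bromophenyl of compound 2 on the aromatic nitrogen, and the limit now covers most of the series: the limit of > 50000 nM in this assay, at which 3 of the 4 values shown sit. Replacing the 3-sulfamoylphenyl gives an at least 1.1-fold higher number from compound 3 to compound 4 (0.07 log units; that floor lies within the scatter), so the single number for compound 3 still cannot be told apart from the limits, and the new result does not show that the sulfamoyl group matters at this position. The steps from compound 1 and from compound 2 to compound 4 cannot be read, since both partners in each pair stand at a limit.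

The compounds shown leave open how far compound 1, compound 2 and compound 4 lie past the limit, and so whether these aryl groups differ from one another at all. They also leave open whether a phenyl carrying an amine or a carboxylic acid, or a longer chain in place of the aryl group on this nitrogen, would give a value clearly inside the reporting window.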